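Nitrophenyl to cyclopentylethyl: an estimate for compound 4

The source may hold more compounds than are shown below. What is called first, only, known or untested is meant among the compounds shown, and "the series" means these compounds.

Measured in a functional assay on DU-145 cells (Homo sapiens) for cytotoxicity, read by sulforhodamine B assay, with a stated time of 2 days, tested at 100 uM; a higher number here means more inhibition at the concentration tested (going by the name of the read-out), a lower number less inhibition:

compound 1 `CCCc1n[nH]c2c(=O)n(NC(=O)c3ccccc3)c(-c3cccc([N+](=O)[O-])c3)nc12`: 27.8%
compound 2 `O=C(Nn1c(-c2cccc([N+](=O)[O-])c2)nc2c(-c3ccc(Cl)cc3)n[nH]c2c1=O)c1ccccc1`: 94.3%
compound 3 `O=C(Nn1c(-c2cccc([N+](=O)[O-])c2)nc2c(-c3ccc(F)cc3)n[nH]c2c1=O)c1ccccc1`: 90.8%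

Compound 2 gives the highest of the three numbers; compound 3 stands nearest, a number 3.5 percentage points lower from compound 2 to compound 3 (within the scatter), and compound 1 furthest, a number 66.5 percentage points higher from compound 1 to compound 2 (beyond the scatter). The two measured steps of size, a number 66.5 percentage points higher from compound 1 to compound 2 (beyond the scatter) and a number 63 percentage points higher from compound 1 to compound 3 (beyond the scatter), both concern the carbon that carries propyl in compound 1 and an aryl group in compound 2 and compound 3.

The unmeasured compound 4 `O=C(Nn1c(CCC2CCCC2)nc2c(-c3ccc(Cl)cc3)n[nH]c2c1=O)c1ccccc1` is reached from compound 2 by 2-cyclopentylethyl in place of 3-nitrophenyl on an aromatic carbon. Going by the values given here, no measured pair changes this position, so no step bears on it directly. Among the compounds with values here, the only guide is indirect: in compound 1 a small alkyl at the other aromatic carbon goes with a low inhibition, 27.8%, whereas compound 2 with an aryl there gives 94.3%. By loose analogy, an alkyl chain in place of an aryl at the present position is expected to lower the number, but the size of that step is uncertain.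

The step from compound 2 to compound 4 in this assay is therefore estimated as a number 39.3 percentage points lower from compound 2 to compound 4 (beyond the scatter). Compound 4 is expected to give about 55%, within 20% to 90%.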

Compound 4, a percentage reported as inhibition, at one concentration (the size of the read-out at that concentration, not a potency): 89.6%
Beside the measured number, compound 4's estimate is 34.6 percentage points below it; the measured number falls inside the stated range.
By their numbers in this assay, from the lowest: compound 1; then compounds 4, 3 and 2 (each within the scatter of the next).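

In this assay, the aromatic carbon between two ring nitrogen atoms accepts 2-cyclopentylethyl in place of 3-nitrophenyl, with a number 4.7 percentage points lower from compound 2 to compound 4 (within the scatter). With 4-chlorophenyl held on the other aromatic carbon, neither the six-membered aromatic ring nor the two hydrogen-bond acceptors of the leaving group are needed for a high number, so the large aryl-to-alkyl contrast at the other carbon, a number 66.5 percentage points higher from compound 1 to compound 2 (beyond the scatter), does not carry over to this position. No supporting data are available to explain why the two positions differ in this way.

Going by these compounds, it remains open whether 2-cyclopentylethyl gives a similar number when propyl or 4-fluorophenyl sits on the other aromatic carbon, and whether a shorter chain such as ethyl, or a chain ending in an amine or a carboxylic acid, would behave like 2-cyclopentylethyl at this position. The read-out at a single concentration also leaves open whether compound 2 and compound 4 are alike in potency, which would take a full concentration series in this assay.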